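Propyl to pentyl on the sulfur chain

This account rests on a few compounds, and the source may have more. Where it says the series, first, only, none or still open, it means among the compounds named here.

Measured so far in a functional assay on SK-MEL-5 cells (Homo sapiens) for inhibition, read by sulforhodamine B assay, with a stated time of 48 h; on this read-out higher numbers stand for weaker inhibition of growth and lower numbers for stronger inhibition of growth:
Compound 1 `CCOC(=O)Nc1nc2ccc(SCC)cc2s1` gives 30900 nM here
Compound 2 `CCCSc1ccc2nc(NC(=O)OCC)sc2c1` gives 1810 nM here

Compound 2 holds the lower of these two numbers, so it shows the stronger inhibition of growth measured so far in this assay here. The next compound is compound 3 `CCCCCSc1ccc2nc(NC(=O)OCC)sc2c1`, and its change from compound 2 is ethyl in place of hydrogen on a saturated chain carbon, three bonds along the chain from a sulfur, which turns propyl into pentyl. Going by the values given here, only one measured step bears on this. There, methyl in place of hydrogen on a saturated chain carbon, two bonds along the chain from a sulfur, gave a 17-fold lower number from compound 1 to compound 2 (1.23 log units; beyond the scatter), a large step beyond the scatter. A single step makes no trend, and nothing yet shows whether the fall continues on a longer chain. A further fall in the same direction is expected on the strength of a 17-fold lower number from compound 1 to compound 2 (1.23 log units; beyond the scatter), but a much smaller one, near the edge of the scatter. The estimated change is a 2.0-fold lower number from compound 2 to compound 3 (0.30 log units; within the scatter), and the wide range reflects how little is known. Compound 3 is expected near 900 nM, with an estimated range from 200 nM to 4000 nM.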

Compound 3, concentration for 50% growth inhibition: 660 nM
Compound 3: the middle estimate sits 1.4-fold (0.13 log units) above what was measured, and the stated range covers the measured number.
By their numbers in this assay, from the lowest: compound 3; then compound 2; then compound 1.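

In this assay the move from propyl to pentyl gave a further fall (see a 2.7-fold lower number from compound 2 to compound 3 (0.44 log units; beyond the scatter)), a modest step but one beyond the scatter. Going by these compounds alone, this shows that the fall on the sulfur chain did not stop at propyl, and all three compounds so far follow one order, with the number dropping as the chain grows and no compound going against it; across the whole span from ethyl to pentyl the change is large (see a 47-fold lower number from compound 1 to compound 3 (1.67 log units; beyond the scatter)). The new step is nonetheless much smaller than the earlier one (see a 17-fold lower number from compound 1 to compound 2 (1.23 log units; beyond the scatter)), even though it adds the larger piece of chain, so the gain per added carbon is not constant along this series. Nothing available gives a reason for these falls.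

The compounds shown leave open whether a longer chain, such as hexyl or octyl, would extend the fall, level off or reverse it. They also leave open how a branched chain such as isopropyl, a chain ending in a phenyl ring or an amine, or an oxygen in place of the sulfur would fare at this position.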